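Swapping the Aryl Group: Expected Effect on Clearance

The source may report more compounds than this note shows. Statements on the series, on what has been measured and on what is new or still open speak of the compounds shown alone.

Three compounds share one core and differ only in the aryl group attached to a single aromatic carbon. Compound 1 `Nc1ccc(S(=O)(=O)N2CCN(c3ncc(C(O)(C(F)(F)F)C(F)(F)F)cc3-c3cccc(F)c3)CC2)cn1`, compound 2 `Nc1ccc(S(=O)(=O)N2CCN(c3ncc(C(O)(C(F)(F)F)C(F)(F)F)cc3-c3ccccc3O)CC2)cn1` and compound 3 `CS(=O)(=O)c1ccc(-c2cc(C(O)(C(F)(F)F)C(F)(F)F)cnc2N2CCN(S(=O)(=O)c3ccc(N)nc3)CC2)cc1` were each tested in an ADME assay (liver) for metabolic stability, with Liver microsome (Homo sapiens) as the target, using microsomes and NADPH, with a stated time of 30 min, tested at 1 uM; a higher number here means faster removal of the compound, a lower number slower removal. Compound 1 gives 25 mL.min-1.g-1, compound 2 gives 22 mL.min-1.g-1 and compound 3 gives 32 mL.min-1.g-1. Among these three numbers compound 1 stands second highest, with compound 2 nearest and compound 3 furthest, yet every step between them remains within the scatter: a 1.1-fold lower number from compound 1 to compound 2 (0.06 log units; within the scatter), a 1.3-fold higher number from compound 1 to compound 3 (0.11 log units; within the scatter) and a 1.5-fold higher number from compound 2 to compound 3 (0.16 log units; within the scatter).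

Compound 4 `Nc1ccc(S(=O)(=O)N2CCN(c3ncc(C(O)(C(F)(F)F)C(F)(F)F)cc3-c3ccc4scnc4c3)CC2)cn1` has not yet been measured. It differs from compound 1 in one place: 1,3-benzothiazol-5-yl in place of 3-fluorophenyl on an aromatic carbon.

All three measured steps bear on this change, since each one exchanges the aryl group on the same aromatic carbon for a different aryl group, and none of them moved the read-out beyond the scatter. The expected step in this assay is therefore a 1.1-fold higher number from compound 1 to compound 4 (0.03 log units; within the scatter), which means no change beyond the scatter in either direction. Compound 4 is estimated to give 27 mL.min-1.g-1, with a likely range from 14 mL.min-1.g-1 to 55 mL.min-1.g-1.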

Compound 4, intrinsic clearance in microsomes: 39 mL.min-1.g-1
For compound 4 the middle estimate is 1.4-fold (0.16 log units) below the measured one; the range from low to high includes it.
By their numbers in this assay, from the lowest: compounds 2, 1, 3 and 4 (each within the scatter of the next).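

In this assay, exchanging a single aromatic ring for the two-ring 1,3-benzothiazol-5-yl group, with 9 heavy atoms in place of the 7 of 3-fluorophenyl, leaves every comparison within the scatter: a 1.6-fold higher number from compound 1 to compound 4 (0.19 log units; within the scatter), a 1.2-fold higher number from compound 3 to compound 4 (0.09 log units; within the scatter) and a 1.8-fold higher number from compound 2 to compound 4 (0.25 log units; within the scatter). The earlier compounds shown here showed this only for aryl groups with a single ring, so compound 4 extends the finding at this aromatic carbon, ortho to a large group, to a larger fused group that adds a five-membered aromatic ring with 2 hetero atoms. No accompanying measurement offers an explanation for these numbers.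

Going by these compounds, all four compounds carry an aromatic ring at this carbon, so it remains open whether an amine, a carboxylic acid or a short alkyl chain there would shift intrinsic clearance in microsomes beyond the scatter. The 2,2,2-trifluoro-1-hydroxy-1-(trifluoromethyl)ethyl group is also the same throughout, which leaves the effect of replacing it, for example with a simple hydroxymethyl group, unknown.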